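The source may report more compounds than this note shows. Statements on the series, on what has been measured and on what is new or still open speak of the compounds shown alone.

Of the compounds shown here, two have been measured. Compound 1, with the structure `COc1ccc(S(=O)(=O)N(Cc2ccc(Cl)c([N+](=O)[O-])c2)[C@H](C)C(=O)NO)cc1`, gives 30 nM in an assay on isolated protein for inhibition of bone morphogenetic protein 1 (Homo sapiens); on this read-out higher numbers stand for weaker inhibition and lower numbers for stronger inhibition. Compound 2, with the structure `COc1ccc(S(=O)(=O)N(Cc2ccc(C(C)C)cc2)[C@H](C)C(=O)NO)cc1`, gives 230 nM in this assay. Of the two numbers, compound 2 has the higher one, and the gap between it and compound 1 lies beyond the usual scatter of repeated measurements, so compound 2 is the weaker inhibitor of the pair.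

Compound 3, with the structure `COc1ccc(S(=O)(=O)N(Cc2cc(C)on2)[C@H](C)C(=O)NO)cc1`, has not yet been measured. It differs from compound 2 in one place: 5-methyl-1,2-oxazol-3-yl in place of 4-isopropylphenyl on a saturated chain carbon bound to a sulfonamide nitrogen. Among the measured compounds shown here, nothing among the measured compounds shows how this kind of exchange, a smaller ring with two hetero atoms in place of a carbon-only ring bearing an isopropyl group, shifts the numbers in this assay. The expectation is therefore cautious: compound 3 is expected to give a number slightly above that of compound 2, possibly at the edge of the scatter, as a step of a 1.7-fold higher number from compound 2 to compound 3 (0.24 log units; within the scatter). Compound 3 is estimated at 400 nM, within a range from 120 nM to 1500 nM.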

Compound 3, half-maximal inhibitory concentration: 230 nM
Estimate against measurement, compound 3: 1.7-fold (0.24 log units) above; the measured number falls inside the stated range.
By their numbers in this assay, from the lowest: compound 1; then compounds 2 and 3 (each within the scatter of the next).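

In this assay, putting 5-methyl-1,2-oxazol-3-yl in place of 4-isopropylphenyl on a saturated chain carbon bound to a sulfonamide nitrogen gives no change at the digits printed from compound 2 to compound 3 (within the scatter). Among the compounds shown here, this is the first view of a single change at this position, and it shows that the number can hold steady through a large change in the group: 9 heavy atoms give way to 6, a six-membered aromatic ring of carbon only gives way to a five-membered aromatic ring with 2 hetero atoms, and 0 hydrogen-bond acceptors become 2. No measurement shown here explains why these two different groups give the same number.

The compounds shown leave open which feature of 5-methyl-1,2-oxazol-3-yl matters, if any, as its methyl group, its hetero atoms and its ring size all change together in this one exchange. Also open, from the compounds shown here alone, is how far this steadiness extends, which a plain phenyl, a pyridine ring, or a longer chain ending in an amine or a carboxylic acid at the same place could help to show.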